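Same Sulfanyl Thiadiazole Swap Tested on a Second Core

The source may report more compounds than this note shows. Statements on the series, on what has been measured and on what is new or still open speak of the compounds shown alone.

Compound 1 `O=[N+]([O-])c1ccc(-c2nc(CO[C@@H]3O[C@H](CO)[C@H]4OC5(CCCC5)O[C@@H]34)no2)cc1` and compound 2 `Nc1nnc(SC[C@H]2O[C@@H](OCc3noc(-c4ccc([N+](=O)[O-])cc4)n3)[C@@H]3OC4(CCCC4)O[C@@H]32)s1` share one core, while compound 3 `CC1(C)O[C@H]2[C@H](OCc3noc(-c4ccc([N+](=O)[O-])cc4)n3)O[C@H](CO)[C@H]2O1` and compound 4 `CC1(C)O[C@H]2[C@H](OCc3noc(-c4ccc([N+](=O)[O-])cc4)n3)O[C@H](CSc3nnc(N)s3)[C@H]2O1` share another; the difference between the two cores is not broken down here. In a functional assay on HBL-100 cells (Homo sapiens) for antiproliferative activity, read by sulforhodamine B assay, with a stated time of 48 h (a higher number here means a weaker inhibitor of growth, a lower number a stronger inhibitor of growth), compound 1 gives 17000 nM and compound 2 gives 26000 nM. The change between them is (5-amino-1,3,4-thiadiazol-2-yl)sulfanyl in place of hydroxy on a saturated chain carbon bound to a saturated ring carbon and it produced a 1.5-fold higher number from compound 1 to compound 2 (0.18 log units; within the scatter). Compound 3 gives 99000 nM in this assay, the highest of the three numbers, and its gap to compound 2 as well as to compound 1 lies beyond the scatter.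

Compound 4 carries the same change as compound 2, now made on the core of compound 3: (5-amino-1,3,4-thiadiazol-2-yl)sulfanyl in place of hydroxy on a saturated chain carbon bound to a saturated ring carbon. The place of the change is described in the same words for both pairs, so it is treated as the same change, seen once among the measured compounds. Within the data shown here, the expectation for compound 4 rests on compound 1 and compound 2 alone, because the only measured instance of this change gave a 1.5-fold higher number from compound 1 to compound 2 (0.18 log units; within the scatter). The step from compound 3 to compound 4 is therefore expected to be small, about a 1.4-fold higher number from compound 3 to compound 4 (0.15 log units; within the scatter). Compound 4 is estimated at roughly 140000 nM, with a range from 60000 nM to 300000 nM. Since compound 3 already stands high, this assay may well report only a limit for compound 4 rather than a number.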

Compound 4, concentration for 50% growth inhibition: > 100000 nM
Compound 4 was reported as a limit (the forecaster's own chance of this, stated with the estimate: 30%); the middle value lies beyond the limit too.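

In this assay compound 4 is reported only as a limit, > 100000 nM, and not as an exact number. The step therefore reads a number no lower from compound 3 to compound 4 (the limit leaves the size open), and the comparison with the same change on the other core stays incomplete: the same change on two cores in this assay, a 1.5-fold higher number (0.18 log units; within the scatter) from compound 1 to compound 2 and a number no lower (the limit leaves the size open) from compound 3 to compound 4; the limit leaves it open whether they differ

The result shows only that putting (5-amino-1,3,4-thiadiazol-2-yl)sulfanyl in place of hydroxy on the core of compound 3 gave no lower number in this assay; it does not show that the change acts alike on the two cores, and it does not show that it acts differently.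

The compounds shown leave open how far compound 4 really stands from compound 3, and so whether this change carries from one core to the other with a similar size. They also leave open what other groups would do on a saturated chain carbon bound to a saturated ring carbon on either core, for example a plain amine or a carboxylic acid in place of hydroxy.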